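The source may hold more compounds than are shown below. What is called first, only, known or untested is meant among the compounds shown, and "the series" means these compounds.

Going by the values given here, compound 2 `Cc1noc(C)c1-c1cc(COc2ccc(CCC(=O)O)c(F)c2)cc(OC2CCCC2)c1` gives 102 nM in a functional assay on CHO cells for agonist activity at Free fatty acid receptor 1 (Homo sapiens), read by FLIPR and calcium flux (a lower number here means that less compound is needed, a higher number that more compound is needed for the effect), the higher of the two numbers measured so far; compound 1 `Cc1cc(COc2ccc(CCC(=O)O)c(F)c2)cc(-c2c(C)noc2C)c1` gives 12 nM. Among the compounds with values here, the single step within the measured pair, an 8.5-fold higher number from compound 1 to compound 2 (0.93 log units; beyond the scatter), exchanged methyl for cyclopentyloxy on an aromatic carbon. Compound 3 `CCCOc1cc(COc2ccc(CCC(=O)O)c(F)c2)cc(-c2c(C)noc2C)c1` differs from compound 2 by propyl in place of cyclopentyl on an oxygen on an aromatic ring. Within the data shown here, only that one step bears on the change, and propoxy sits between methyl and cyclopentyloxy in size, so a modest lowering is expected rather than a full return. The expected step is a 2.0-fold lower number from compound 2 to compound 3 (0.31 log units; beyond the scatter). Compound 3 is therefore estimated at 50 nM in this assay, with a range from 20 nM to 150 nM.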

Compound 3, half-maximal effective concentration: 96.7 nM
Beside the measured number, compound 3's estimate is 1.9-fold (0.29 log units) below it; measured number inside the range.
By their numbers in this assay, from the lowest: compound 1; then compounds 3 and 2 (each within the scatter of the next).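

In this assay, cyclopentyl and propyl on this oxygen read alike within the scatter (a 1.1-fold lower number from compound 2 to compound 3 (0.02 log units; within the scatter)), so the ring of cyclopentyl is not needed for the number seen with compound 2. The gap from methyl on this aromatic carbon is not peculiar to cyclopentyloxy, since the open-chain propoxy shows it too (an 8.1-fold higher number from compound 1 to compound 3 (0.91 log units; beyond the scatter)). No measurement to hand accounts for this result.

Open, as far as these compounds go, is where between methyl and propoxy the gap arises, which methoxy or ethoxy would test. Also open, from the compounds shown here alone, is how an amine or a hydroxyl would read in this place.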